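The compounds below may be only part of what the source reports. "The series", "measured", "known", "first", "only" and "open" are said of these compounds alone.

Notes on the series: in a functional assay on HeLa cells (Homo sapiens) for antiproliferative activity, read by resazurin assay (on this read-out lower numbers stand for stronger inhibition and higher numbers for weaker inhibition), compound 2 (`CCSC(=S)SCC(=O)c1ccccc1`) gives 5010 nM. Among the compounds with values here, this is the lower of the two numbers measured so far, and the gap to compound 1 (`CCSC(=S)SCC(=O)c1ccc(OC)cc1OC`), which gives 12600 nM, lies beyond the usual scatter. Compound 2 therefore stands as the stronger inhibitor of this pair.

The next compound to be measured is compound 3 (`CCSC(=S)SCC(=O)c1ccccc1OC`), with methoxy in place of hydrogen on an aromatic carbon of compound 2: methoxy in place of hydrogen on an aromatic carbon.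

Within the data shown here, no single-site step between measured compounds is available, so the expectation rests on thin evidence. Among the measured compounds shown here, the only measured compound with methoxy on the ring is compound 1 at 12600 nM, which has a higher number than compound 2 at 5010 nM. A small step towards weaker inhibition is therefore expected in this assay, though one that stays within the scatter cannot be excluded. The expected step is a 1.6-fold higher number from compound 2 to compound 3 (0.20 log units; within the scatter). For compound 3 the estimated value is 8000 nM, with an expected range from 3500 nM to 18000 nM.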

Compound 3, half-maximal inhibitory concentration: 15800 nM
Estimate against measurement, compound 3: 2.0-fold (0.30 log units) below, and the stated range covers the measured number.
By their numbers in this assay, from the lowest: compound 2; then compounds 1 and 3 (each within the scatter of the next).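

Within the data shown here, with this assay as the read-out, placing methoxy on the aromatic carbon ortho to the group of 9 heavy atoms gives a 3.2-fold higher number from compound 2 to compound 3 (0.50 log units; beyond the scatter) as the first single-site reading for this position, a modest move towards weaker inhibition from the unsubstituted ring of compound 2. Removing the other methoxy of compound 1 leaves this position occupied and gives a 1.3-fold higher number from compound 1 to compound 3 (0.10 log units; within the scatter) as the second reading, so that methoxy shows no effect that can be told apart from the scatter. On these two steps the move towards weaker inhibition goes with the methoxy at this position, while the other methoxy of compound 1 adds no step beyond the scatter.

Still open, as far as these compounds go, is whether the step belongs to methoxy as such or would also appear with fluorine, hydroxyl or a longer ethoxy group at this position. Also open, from the compounds shown here alone, is what an amine or a longer chain in place of the ethyl group would do to the number.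

No measurement of any property of these groups is at hand to explain either step.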